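Acetyl to dimethylamino on the pendant phenyl ring

The source may report more compounds than this note shows. Statements on the series, on what has been measured and on what is new or still open speak of the compounds shown alone.

Measured compounds:
compound 1 `COc1cc(C)cc(-c2c(-c3ccnc(-c4ccc(C(C)=O)cc4)c3)cnn2CC#N)c1` — in a functional assay on RPMI8266 cells (Homo sapiens) for inhibition, read by sulforhodamine B assay, with a stated time of 48 h (a lower number here means a stronger inhibitor of growth, a higher number a weaker inhibitor of growth), compound 1 gives 2590 nM
compound 2 `Cc1cc(O)cc(-c2nn(CC#N)cc2-c2ccnc(-c3ccc(Oc4ccccc4)cc3)c2)c1` — in this assay compound 2 gives 2250 nM

Compound 1 has the higher of the two numbers, but the gap to compound 2 is within the scatter of repeated measurements, so no order between the two can be drawn. Compound 3 `COc1cc(C)cc(-c2c(-c3ccnc(-c4ccc(N(C)C)cc4)c3)cnn2CC#N)c1` is not yet measured; it differs from compound 1 in one place: dimethylamino in place of acetyl on an aromatic carbon. Within the data shown here, no measured pair shows this change, so nothing here tells its size or direction. The expectation rests only on the two numbers above, which sit close together; a step of modest size, in either direction, is expected from compound 1 to compound 3, with the step of a 1.3-fold lower number from compound 1 to compound 3 (0.11 log units; within the scatter) as the working guess. Compound 3 is expected to give 2000 nM in this assay, within a range of 600 nM to 7000 nM.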

Compound 3, concentration for 50% growth inhibition: 266 nM
Beside the measured number, compound 3's estimate is 7.5-fold (0.88 log units) above it; measured number outside the range, below it.
By their numbers in this assay, from the lowest: compound 3; then compounds 2 and 1 (each within the scatter of the next).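

In this assay the group on the pendant phenyl ring is not interchangeable: dimethylamino in place of acetyl on the aromatic carbon para to a large group gives a clear step (a 9.7-fold lower number from compound 1 to compound 3 (0.99 log units; beyond the scatter)). The groups that leave and enter have the same count of heavy atoms and hydrogen-bond acceptors, and neither has a hydrogen-bond donor, so these counts do not separate compound 1 from compound 3. Nothing measured on these compounds accounts for the step.

On these data alone, whether the step belongs to dimethylamino alone or extends to a primary amine, pyrrolidine or morpholine at the same place remains open. Also open, as far as these compounds go, is whether methoxy or a carboxylic acid there would give a number closer to compound 1 or to compound 3.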